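Series notes: para-aryl variation on a shared sulfonamide core

This account rests on a few compounds, and the source may have more. Where it says the series, first, only, none or still open, it means among the compounds named here.

Measured so far in a functional assay on NCI-H460 cells (Homo sapiens) for inhibition, with a stated time of 72 h; on this read-out higher numbers stand for weaker inhibition and lower numbers for stronger inhibition:
compound 1 `COc1ccc(S(=O)(=O)N2CCc3cccc(-c4ccc([N+](=O)[O-])cc4)c32)cc1`: 53.1 nM
compound 2 `COc1ccc(S(=O)(=O)N2CCc3cccc(-c4ccc(F)cc4)c32)cc1`: 95.5 nM
compound 3 `COc1ccc(S(=O)(=O)N2CCc3cccc(-c4ccc(O)cc4)c32)cc1`: 114 nM

Compound 3 gives the highest number of the three. Going by the values given here, its nearest neighbour is compound 2, with a 1.2-fold higher number from compound 2 to compound 3 (0.08 log units; within the scatter), a difference inside the scatter; the only step beyond the scatter is a 2.1-fold higher number from compound 1 to compound 3 (0.33 log units; beyond the scatter), and a 1.8-fold higher number from compound 1 to compound 2 (0.25 log units; within the scatter) stays inside it. On these numbers the three aryl groups are barely told apart.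

Compound 4 `COc1ccc(S(=O)(=O)N2CCc3cccc(-c4ccc(F)nc4)c32)cc1` follows from compound 3 by 6-fluoropyridin-3-yl in place of 4-hydroxyphenyl on an aromatic carbon. The step that bears on this is a 1.2-fold higher number from compound 2 to compound 3 (0.08 log units; within the scatter): swapping hydroxy and fluoro on that ring moved nothing beyond the scatter. Among the compounds with values here, no measured compound carries a ring nitrogen at this position, so the pyridine part of the change has no precedent here; it must be taken as neutral. Compound 4 is therefore expected near compound 2 and compound 3, with a 1.3-fold lower number from compound 3 to compound 4 (0.13 log units; within the scatter) inside the scatter. The estimate for compound 4 is 85 nM, between 40 nM and 180 nM.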

Compound 4, half-maximal inhibitory concentration: 135 nM
Compound 4: middle estimate off by 1.6-fold (0.20 log units), on the low side; measured number inside the range.
By their numbers in this assay, from the lowest: compounds 1, 2, 3 and 4 (each within the scatter of the next, the first and the last beyond it).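

In this assay, the first ring nitrogen at this position leaves the number unresolved from those of the phenyl compounds: a 1.2-fold higher number from compound 3 to compound 4 (0.07 log units; within the scatter) and a 1.4-fold higher number from compound 2 to compound 4 (0.15 log units; within the scatter) both stay inside the scatter. The change from 4-nitrophenyl does go beyond it, at a 2.5-fold higher number from compound 1 to compound 4 (0.41 log units; beyond the scatter), but that gap is modest, and compound 1 is still not separated from compound 2, so the four aryl groups span only a narrow band. Nothing available gives a reason for any of these steps.

Still open, going by these compounds, is whether an aryl group carrying an amine or a carboxylic acid, or a saturated ring such as morpholine in place of the aryl group, would leave that band. Also open, on these data alone, is whether a pyridine without the fluoro group would behave like compound 4.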